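This account rests on a few compounds, and the source may have more. Where it says the series, first, only, none or still open, it means among the compounds named here.

Compound 1 `CC(C)(C)OC(=O)N1CCC(Oc2ncnc3c2CCN3c2ccc(S(C)(=O)=O)cc2F)CC1` gives the highest of the three maximal responses in a functional assay on CHO-K1 cells with Glucose-dependent insulinotropic receptor (Homo sapiens) as the target, read by a luciferase reporter, with a stated time of 5 h (on this read-out lower numbers stand for smaller maximal responses and higher numbers for larger maximal responses), with 139%. Compound 2 `COCCOC(=O)N1CCC(Oc2ncnc3c2CCN3c2ccc(S(C)(=O)=O)cc2F)CC1` gives 86% in this assay, and compound 3 `CS(=O)(=O)c1ccc(N2CCc3c(OC4CCN(C(=S)Sc5ccccc5)CC4)ncnc32)c(F)c1` gives 103%. Compound 4 `CN(C)S(=O)(=O)N1CCC(Oc2ncnc3c2CCN3c2ccc(S(C)(=O)=O)cc2F)CC1` differs from compound 1 in one place: dimethylsulfamoyl in place of tert-butoxycarbonyl on an amine nitrogen in a ring. The two measured steps that change the same group on the same nitrogen both run downward and beyond the scatter: a number 53 percentage points lower from compound 1 to compound 2 (beyond the scatter) and a number 36 percentage points lower from compound 1 to compound 3 (beyond the scatter). On that basis a downward step in this assay is expected for compound 4 as well, of a size between those two, a number 39 percentage points lower from compound 1 to compound 4 (beyond the scatter). Compound 4 is therefore estimated at 100%, with a range of 70% to 130%.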

Compound 4, largest response reached (reported as percent of maximum), in percent of the reference or control that the assay uses: 68%
Compound 4: middle estimate off by 32 percentage points, on the high side; measured number below the stated range.
By their numbers in this assay, from the lowest: compound 4; then compound 2; then compound 3; then compound 1.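

Dimethylsulfamoyl in place of tert-butoxycarbonyl gives the largest fall yet on this amine nitrogen, with a number 71 percentage points lower from compound 1 to compound 4 (beyond the scatter) in the maximal response. It also falls short of the other two replacements, with a number 18 percentage points lower from compound 2 to compound 4 (beyond the scatter) and a number 35 percentage points lower from compound 3 to compound 4 (beyond the scatter) as the steps, so compound 4 is the lowest of the four. All three replacements lower the response, and none goes against that within these compounds. Still open, as far as these compounds go, is whether a simple acetyl group, a methanesulfonyl group or a urea on this nitrogen would restore the response of compound 1. No data shown here bear on why the response falls.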